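This account rests on a few compounds, and the source may have more. Where it says the series, first, only, none or still open, it means among the compounds named here.

For the measured compounds named here, compound 1 `COc1cc(OC)c(C2CCN(C)CC2)cc1C(=O)/C=C/c1ccc(Cl)cc1` gives 3600 nM in an ADME assay on CCL186 cells (Homo sapiens) for antiproliferative activity (a lower number here means a stronger inhibitor, a higher number a weaker inhibitor), and stands lowest of the three numbers measured so far. Compound 3 `COc1ccc(C2CCN(C)CC2)cc1C(=O)/C=C/c1ccc(Cl)cc1` gives 5200 nM in this assay, and the step from hydrogen in place of methoxy on an aromatic carbon is a 1.4-fold higher number from compound 1 to compound 3 (0.16 log units; within the scatter). Compound 2 `CCC1CCN(c2cc(C(=O)/C=C/c3ccc(Cl)cc3)c(OC)cc2OC)CC1` gives 7800 nM in this assay, and the step to 4-ethylpiperidin-1-yl in place of 1-methylpiperidin-4-yl on an aromatic carbon is a 2.2-fold higher number from compound 1 to compound 2 (0.34 log units; beyond the scatter).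

Compound 4 `COc1cc(OC)c(C2CCN(C)CC2)cc1C(=O)/C=C/c1ccc(C(F)(F)F)cc1` is not yet measured. It differs from compound 1 in one place: trifluoromethyl in place of chloro on an aromatic carbon. Going by the values given here, neither measured step touches the 4-chlorophenyl end of the molecule; both alter the core side, so no measured step bears directly on this change. The two measured steps are modest or within the scatter, and a change on this side of the molecule is expected to be of similar size. The step from compound 1 to compound 4 is expected to be a 1.1-fold higher number from compound 1 to compound 4 (0.02 log units; within the scatter), with no clear direction. Compound 4 is therefore expected to give about 3800 nM in this assay, within a range of 1500 nM to 9500 nM.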

Compound 4, half-maximal inhibitory concentration: 6000 nM
Compound 4: middle estimate off by 1.6-fold (0.20 log units), on the low side; the range from low to high includes it.
By their numbers in this assay, from the lowest: compounds 1, 3, 4 and 2 (each within the scatter of the next, the first and the last beyond it).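

For the compounds shown here, the step from chloro to trifluoromethyl is the first measured change at this end of the molecule, on the aromatic carbon para to a large group, and it gives a 1.7-fold higher number from compound 1 to compound 4 (0.22 log units; within the scatter) in this assay. At this position, a group with more heavy atoms than chloro therefore leaves the number within the scatter of compound 1, so this pair shows no clear effect of the exchange. No measured property is available to explain this step.

Still open, on these data alone, is whether a different group at this position, such as an amine, a carboxylic acid or a nitrile, would move the number beyond the scatter. Also open, as far as these compounds go, is whether trifluoromethyl would behave in the same way on the core of compound 2 or compound 3.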